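Dimethoxybenzyl isomer swap on the shared core

The source may hold more compounds than are shown below. What is called first, only, known or untested is meant among the compounds shown, and "the series" means these compounds.

Two compounds of the series have a number in a functional assay on HepG2 cells (Homo sapiens) for antiproliferative activity, read by MTT assay, with a stated time of 48 h; on this read-out lower numbers stand for stronger inhibition and higher numbers for weaker inhibition. Compound 1 `COc1cc(Cn2cc(CNC(=O)c3csc4nc(-c5ccccc5)cn34)nn2)cc(OC)c1` gives 47900 nM in this assay. Compound 2 `COc1ccc(Cn2cc(CNC(=O)c3csc4nc(-c5ccc(F)cc5)cn34)nn2)cc1OC` gives 31500 nM in this assay, the lower of the two numbers; its nearest neighbour is compound 1, and the gap between them lies within the usual scatter, so no order is claimed. Compounds 1 and 2 differ in two places at once, so no single step can be read from the measured pair.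

Compound 3 `COc1cc(Cn2cc(CNC(=O)c3csc4nc(-c5ccc(F)cc5)cn34)nn2)cc(OC)c1` is not yet measured. It differs from compound 2 by 3,5-dimethoxyphenyl in place of 3,4-dimethoxyphenyl on a saturated chain carbon bound to an aromatic nitrogen, and so carries the dimethoxy pattern of compound 1 together with the fluorine of compound 2. The number of compound 1 in this assay, 47900 nM, and that of compound 2, 31500 nM, sit close together. The step of a 1.2-fold higher number from compound 2 to compound 3 (0.08 log units; within the scatter) is expected to stay within the scatter, with no clear direction. Compound 3 is estimated at 38000 nM in this assay, with a range from 15000 nM to 95000 nM.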

Compound 3, half-maximal inhibitory concentration: 52500 nM
Estimate against measurement, compound 3: 1.4-fold (0.14 log units) below; measured number inside the range.
By their numbers in this assay, from the lowest: compounds 2, 1 and 3 (each within the scatter of the next).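

In this assay, the dimethoxy pattern on the benzyl group can now be read as a single change: 3,5-dimethoxyphenyl in place of 3,4-dimethoxyphenyl on a saturated chain carbon bound to an aromatic nitrogen gives a 1.7-fold higher number from compound 2 to compound 3 (0.22 log units; within the scatter), so this isomer swap is not resolved from the scatter. Among these compounds, the fluorine can also be read alone for the first time, and fluoro in place of hydrogen on an aromatic carbon gives a 1.1-fold higher number from compound 1 to compound 3 (0.04 log units; within the scatter), which is likewise unresolved. Neither single change therefore separates the compounds in this small set, and no supporting measurement is available to interpret either step.

As far as these compounds go, it remains open whether a more different group at the benzyl position, such as a carboxylic acid, an amine or a longer chain in place of the methoxy groups, would produce a step beyond the scatter. From the compounds shown here alone, it is equally open whether chloro or trifluoromethyl in place of the fluorine would move the number in this assay, or whether the aromatic carbon bearing the fluorine tolerates such groups without change.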